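Methyl Replaces Chloro in a Series Without Measurable Cytotoxicity

The source may hold more compounds than are shown below. What is called first, only, known or untested is meant among the compounds shown, and "the series" means these compounds.

Compound 3 `N#Cc1c(-c2ccc(Cl)cc2)c(C#N)c(=O)n(/N=C/c2cn(-c3ccccc3)nc2-c2ccccc2)c1N` is one of three related compounds tested in an ADME assay on HeLa cells (Homo sapiens) for cytotoxicity, read by MTT assay; a lower number here means a stronger inhibitor, a higher number a weaker inhibitor. In this assay compound 3 gives only a limit, > 200 ug/mL. Compound 1 `N#Cc1c(-c2ccccc2)c(C#N)c(=O)n(/N=C/c2cn(-c3ccccc3)nc2-c2ccccc2)c1N` likewise reaches only a limit in this assay, > 200 ug/mL. Compound 2 `N#Cc1c(-c2ccccc2Cl)c(C#N)c(=O)n(/N=C/c2cn(-c3ccccc3)nc2-c2ccccc2)c1N` also stops at a limit in this assay, > 200 ug/mL. Because (the limit of > 200 ug/mL in this assay, at which 3 of the 3 values shown sit), the steps among them cannot be read: a step that the two limits leave unreadable from compound 1 to compound 2, a step that the two limits leave unreadable from compound 1 to compound 3 and a step that the two limits leave unreadable from compound 2 to compound 3. None of these measured steps carries a readable size onto the change from compound 3 to compound 4 `Cc1ccc(-c2c(C#N)c(N)n(/N=C/c3cn(-c4ccccc4)nc3-c3ccccc3)c(=O)c2C#N)cc1`, which is methyl in place of chloro on an aromatic carbon. For the measured compounds named here, with every measured value sitting at the same limit, the earlier steps give no size to work from, and no step beyond the scatter is expected in this assay in either direction. Compound 4 is therefore expected to give 300 ug/mL, between 150 ug/mL and 700 ug/mL, most likely once more only as a limit. The expected step is a step that the limit leaves unreadable from compound 3 to compound 4.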

Compound 4, half-maximal inhibitory concentration: > 200 ug/mL
Compound 4: a limit, no number; the forecaster's own chance of this, stated with the estimate: 85%; the middle value lies beyond the limit too.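

No new step can be read between compound 4 and compound 1, compound 2 or compound 3, because all four stop at a limit and give no number: the limit of > 200 ug/mL in this assay, at which 4 of the 4 values shown sit.
The compounds shown leave open whether any of them differs from another in this assay at all, and at what concentration each would reach half-maximal inhibition.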